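Swapping the benzylic aryl: from dimethoxyphenyl to naphthyl

The compounds below may be only part of what the source reports. "The series", "measured", "known", "first", "only" and "open" are said of these compounds alone.

The series shares one core and varies the aryl group on a saturated chain carbon bound to an amide-type nitrogen in a ring. In a functional assay on K562 cells (Homo sapiens) for antiproliferative activity, read by MTT assay, with a stated time of 48 h (a higher number here means a weaker inhibitor, a lower number a stronger inhibitor), compound 1 `COc1ccc(-c2ccc3c(c2)C(=O)C(=O)N3Cc2ccc(Br)cc2)cc1` gives 100 nM. Its counterpart compound 2 `COc1ccc(-c2ccc3c(c2)C(=O)C(=O)N3Cc2ccc(OC)c(OC)c2)cc1` gives 60 nM in this assay, so there is a 1.7-fold lower number from compound 1 to compound 2 (0.22 log units; within the scatter). Among the two numbers measured so far, compound 2 shows the lower one, but its only neighbour is compound 1, whose value sits within the scatter of it, so no order between them can be claimed.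

Compound 3 `COc1ccc(-c2ccc3c(c2)C(=O)C(=O)N3Cc2ccc3ccccc3c2)cc1` is the next member, differing from compound 2 by naphthalen-2-yl in place of 3,4-dimethoxyphenyl on a saturated chain carbon bound to an amide-type nitrogen in a ring. Among the compounds with values here, the one measured step that bears on this change is the aryl-for-aryl exchange at the same place, a 1.7-fold lower number from compound 1 to compound 2 (0.22 log units; within the scatter), which stayed within the scatter. On that basis, compound 3 is expected to show no step beyond the scatter in this assay, meaning an expected 1.3-fold higher number from compound 2 to compound 3 (0.12 log units; within the scatter). The estimate for compound 3 in this assay is therefore 80 nM, with a range from 30 nM to 250 nM.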

Compound 3, half-maximal inhibitory concentration: 400 nM
The estimate for compound 3 lay 5.0-fold (0.70 log units) below the measured number, outside the stated range (above it).
By their numbers in this assay, from the lowest: compounds 2 and 1 (each within the scatter of the next); then compound 3.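

In this assay, this position does not accept every aryl group equally: naphthalen-2-yl in place of 3,4-dimethoxyphenyl gives a 6.7-fold higher number from compound 2 to compound 3 (0.82 log units; beyond the scatter), and in place of 4-bromophenyl it gives a 4.0-fold higher number from compound 1 to compound 3 (0.60 log units; beyond the scatter), whereas the two groups with one six-membered aromatic ring could not be ordered. Compound 1 carries no methoxy group and still lies within the scatter of compound 2, so among these three compounds, losing the two oxygen atoms of 3,4-dimethoxyphenyl does not by itself go with a higher number, and the compound that stands apart is the one with 2 six-membered aromatic rings. Nothing at hand explains why the number rises with this change.

The three compounds leave open whether any group with a second aromatic ring at this place gives the same rise, or whether it holds only for naphthalen-2-yl, as naphthalen-1-yl or a quinoline ring carrying a ring nitrogen could show. They also leave open how a plain unsubstituted phenyl group, or a single methoxy group on the phenyl ring, would compare with compound 1 and compound 2.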